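The compounds below may be only part of what the source reports. "The series", "measured", "known", "first", "only" and "open" are said of these compounds alone.

Series notes. Compound 1 `CCCCCCn1cnc2c(Nc3cccc(Cl)c3)nc(N[C@H]3CC[C@H](N)CC3)nc21` gives 2300 nM in a functional assay on K562 cells (Homo sapiens) for inhibition, read by fluorescence, with a stated time of 72 h; a higher number here means a weaker inhibitor of growth, a lower number a stronger inhibitor of growth. Compound 2 `CC(C)=CCn1cnc2c(Nc3cccc(Cl)c3)nc(N[C@H]3CC[C@H](N)CC3)nc21` gives 3500 nM in this assay, and compound 3 `COc1ccc(Cn2cnc3c(Nc4cccc(Cl)c4)nc(N[C@H]4CC[C@H](N)CC4)nc32)cc1` gives 2800 nM. All three measured steps change the group on the saturated chain carbon bound to an aromatic nitrogen: a 1.5-fold higher number from compound 1 to compound 2 (0.18 log units; within the scatter), a 1.2-fold higher number from compound 1 to compound 3 (0.09 log units; within the scatter) and a 1.3-fold lower number from compound 2 to compound 3 (0.10 log units; within the scatter). Compound 1 holds the lowest of the three numbers, but its gaps to compound 3 and to compound 2 both fall within the scatter, so no order among the three can be read.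

Compound 4 `CCCCCCn1cnc2c(Nc3cc(OC)cc(OC)c3)nc(N[C@H]3CC[C@H](N)CC3)nc21` differs from compound 1 at another place: 3,5-dimethoxyphenyl in place of 3-chlorophenyl on a nitrogen on an aromatic ring. Within the data shown here, none of the measured steps touches the group on the nitrogen on the aromatic ring, so no measured step bears directly on this change; the measured steps show only that varying the other end leaves the numbers close together. With no measured guide for this change, compound 4 is expected to give 3000 nM, within 800 nM to 12000 nM. The expected step is a 1.3-fold higher number from compound 1 to compound 4 (0.12 log units; within the scatter), and the wide range reflects the absence of any measured comparison for this position.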

Compound 4, concentration for 50% growth inhibition: 1900 nM
The estimate for compound 4 lay 1.6-fold (0.20 log units) above the measured number; low and high end bracket the measured number.
By their numbers in this assay, from the lowest: compounds 4, 1, 3 and 2 (each within the scatter of the next).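

Among these compounds, the only measured change at the nitrogen on an aromatic ring, 3,5-dimethoxyphenyl in place of 3-chlorophenyl, gives a 1.2-fold lower number from compound 1 to compound 4 (0.08 log units; within the scatter) in this assay. For this one pair, then, going from 0 hydrogen-bond acceptors to 2 in this group leaves the number within the scatter, as the changes on the saturated chain carbon did at the other end of the molecule. Nothing available explains why the numbers stay so close.

A single pair cannot show whether any group on this nitrogen moves the number beyond the scatter, and a phenyl ring carrying a carboxylic acid or a primary amine would test that more sharply. Also open, as far as these compounds go, is whether 3,5-dimethoxyphenyl behaves the same way alongside the groups of compound 2 and compound 3.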